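Trifluoromethyl for Methyl on the Sulfonyl Aryl Ring

This account rests on a few compounds, and the source may have more. Where it says the series, first, only, none or still open, it means among the compounds named here.

Of the compounds shown here, three sharing one core have been measured in a functional assay on MDA-MB-231 cells (Homo sapiens) for inhibition, read by sulforhodamine B assay, tested at 10 uM; a lower number here means less inhibition, a higher number more inhibition at the concentration tested (going by the name of the read-out). Compound 1 `CN(C)c1ccc(C2CC(c3ccc(-n4cncn4)cc3)=NN2C(=O)CCCl)cc1` gives 3.7%, compound 2 `CN(C)c1ccc(C2CC(c3ccc(-n4cncn4)cc3)=NN2C(=O)c2ccc(C(F)(F)F)cc2)cc1` gives 16.7%, and compound 3 `Cc1ccc(S(=O)(=O)N2N=C(c3ccc(-n4cncn4)cc3)CC2c2ccc(N(C)C)cc2)cc1` gives 20.7%. Compound 3 carries the highest number of the three; its gap to compound 2 lies within the scatter, while a number 17 percentage points higher from compound 1 to compound 3 (beyond the scatter) lies beyond it. Compound 4 `CN(C)c1ccc(C2CC(c3ccc(-n4cncn4)cc3)=NN2S(=O)(=O)c2ccc(C(F)(F)F)cc2)cc1` differs from compound 3 by trifluoromethyl in place of methyl on an aromatic carbon. Among the compounds with values here, no measured step exchanges these two groups directly. The nearest guide is a number 4 percentage points higher from compound 2 to compound 3 (within the scatter), where a trifluoromethyl-bearing ring and a methyl-bearing ring, attached through different groups, gave much the same number. A step within the scatter is therefore expected, a number 1.3 percentage points higher from compound 3 to compound 4 (within the scatter). Compound 4 is estimated at 22%, between 8% and 38%.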

Compound 4, a percentage reported as inhibition, at one concentration (the size of the read-out at that concentration, not a potency): 15.3%
Estimate against measurement, compound 4: 6.7 percentage points above, within the range that was stated.
By their numbers in this assay, from the lowest: compound 1; then compounds 4, 2 and 3 (each within the scatter of the next).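

Within the data shown here, putting 4-(trifluoromethyl)phenyl in place of 4-methylphenyl on the sulfonyl group gives the first direct reading of this change in this assay: a number 5.4 percentage points lower from compound 3 to compound 4 (within the scatter), so the two groups cannot be told apart at this position. The earlier comparison also changed the link to the ring, whereas here only the group on the aromatic carbon differs. Nothing measured explains this result.

Going by these compounds, whether an amine or a carboxylic acid at this place would move the number beyond the scatter remains open. So does whether a longer chain there would do so.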